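An untested acetoxy on a saturated chain carbon

This account rests on a few compounds, and the source may have more. Where it says the series, first, only, none or still open, it means among the compounds named here.

In a functional assay on HCT-15 cells (Homo sapiens) (on this read-out higher numbers stand for an effect only at larger amounts of compound and lower numbers for an effect already at smaller amounts), compound 1 `COc1cc(C2OC(c3ccc(N)c(C)c3)=NN2C(C)=O)cc(OC)c1OC` gives 0.042 uM. Compound 2 `COc1cc(C2OC(c3ccc(N(C)C)cc3)=NN2C(C)=O)cc(OC)c1OC` gives 0.033 uM, level with compound 1 within the scatter. Compound 3 `COc1cc(C2OC(c3ccc(N(C)C)cc3)=NN2C(=O)COC(C)=O)cc(OC)c1OC` differs from compound 2 by acetoxy in place of hydrogen on a saturated chain carbon bound to a carbonyl carbon, with acetoxy in place of hydrogen on a saturated chain carbon bound to a carbonyl carbon. For the measured compounds named here, the one measured step, a 1.3-fold lower number from compound 1 to compound 2 (0.10 log units; within the scatter), lies within the scatter and concerns a different place, so no measurement tests this change. A modest move towards a higher number is expected, an estimated 2.1-fold higher number from compound 2 to compound 3 (0.33 log units; beyond the scatter). Compound 3 is expected at 0.07 uM, within a range of 0.015 uM to 0.35 uM.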

Compound 3, concentration for half-maximal effect: 0.019 uM
Compound 3: middle estimate off by 3.7-fold (0.57 log units), on the high side, within the range that was stated.
By their numbers in this assay, from the lowest: compounds 3, 2 and 1 (each within the scatter of the next, the first and the last beyond it).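

In this assay, the saturated chain carbon bound to a carbonyl carbon now has a measured change: acetoxy in place of hydrogen gives a 1.7-fold lower number from compound 2 to compound 3 (0.24 log units; within the scatter). This place therefore takes acetoxy, with its 4 heavy atoms, without leaving the scatter, and the same difference reads as acetyl to (acetoxymethyl)carbonyl. Nothing available explains this result. Still open, from the compounds shown here alone, is how a hydroxy, an amine or a longer chain on the same carbon would read. Also open, going by these compounds, is whether acetoxy there would read the same alongside the 4-amino-3-methylphenyl of compound 1.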